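The compounds below may be only part of what the source reports. "The series", "measured", "known", "first", "only" and "open" are said of these compounds alone.

Compound 1 `CC(C)(C)OC(=O)/C=C1/C(=O)Nc2ccccc21` sits among three measured compounds whose readings in a functional assay on SK-BR-3 cells (Homo sapiens) for inhibition, read by CCK-8 assay, with a stated time of 72 h, tested at 20 uM (on this read-out higher numbers stand for more inhibition of growth at the one concentration tested and lower numbers for less inhibition of growth), cannot be told apart within the usual scatter. In this assay compound 1 gives 87.3%; compound 2 `CC(C)c1ccc2c(c1)/C(=C\C(=O)OC(C)(C)C)C(=O)N2`, which carries an isopropyl group on the ring, gives 88.5%; and compound 3 `CC(C)(C)OC(=O)/C=C1/C(=O)Nc2ccc(Cl)cc21`, which carries a chloro group on the ring, gives 87.6%. Compound 4 `CC(C)(C)OC(=O)/C=C1/C(=O)Nc2c(Cl)cccc21` has not yet been measured. It differs from compound 1 by chloro in place of hydrogen on an aromatic carbon, placed on an aromatic carbon of a six-membered aromatic ring of carbon only, part of a fused system of two rings, ortho to a fused ring. Among the measured compounds shown here, two measured steps bear on this change: adding a chloro group elsewhere on the same ring gave a number 0.3 percentage points higher from compound 1 to compound 3 (within the scatter), and adding an isopropyl group gave a number 1.2 percentage points higher from compound 1 to compound 2 (within the scatter). Both are within the scatter, so no step beyond the scatter is expected in this assay, in either direction. The estimated step is a number 0.2 percentage points higher from compound 1 to compound 4 (within the scatter). Compound 4 is therefore expected to give about 87.5%, between 77% and 95%.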

Compound 4, percent growth inhibition at one concentration: 88.2%
Compound 4: middle estimate off by 0.7 percentage points, on the low side; the measured number falls inside the stated range.
By their numbers in this assay, from the lowest: compounds 1, 3, 4 and 2 (each within the scatter of the next).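

In this assay, chloro in place of hydrogen on this aromatic carbon, ortho to a fused ring, gives a number 0.9 percentage points higher from compound 1 to compound 4 (within the scatter), so this position takes a chlorine atom without a reading that can be told apart from the unsubstituted compound. Placing chloro elsewhere on the same ring changes no more: compound 3 reads 87.6% and compound 4 reads 88.2%, which are within the usual scatter of each other. Nothing available explains why the reading stays flat at this position.

The compounds shown leave open whether a group other than chloro, such as an amine, a carboxylic acid or a longer alkyl chain, would be accepted on this same carbon. They also leave open whether compound 1 and compound 4 would separate at lower concentrations, since all these readings come from a single concentration.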